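A few compounds are considered here, and "the series" means these few. Any claim that something is new, unique, unknown or untested is made for them only; others in the source may bear on it.

Compound 2 `O=C(NC1CCN(Cc2ccc(OC3CCNCC3)c(Br)c2)CC1)c1cscn1` carries a 1,3-thiazol-4-yl group on the carbonyl carbon. In an assay on HEK293 cells for displacement of a labelled ligand from Urotensin-2 receptor (Homo sapiens), read by fluorescence, with a stated time of 90 min (on this read-out lower numbers stand for stronger inhibition and higher numbers for weaker inhibition), compound 2 gives 970 nM, the highest number among the three measured compounds. Compound 1 `O=C(NC1CCN(Cc2ccc(OC3CCNCC3)c(Br)c2)CC1)c1ccco1` gives 770 nM, and the step of a 1.3-fold higher number from compound 1 to compound 2 (0.10 log units; within the scatter) sits within the scatter. Compound 3 `O=C(NC1CCN(Cc2ccc(OC3CCNCC3)c(Br)c2)CC1)c1ccccn1` gives 120 nM, and the step of an 8.1-fold lower number from compound 2 to compound 3 (0.91 log units; beyond the scatter) goes beyond it. Compound 4 `O=C(NC1CCN(Cc2ccc(OC3CCNCC3)c(Br)c2)CC1)c1cc2cc(Br)ccc2s1` differs from compound 2 in one place: 5-bromo-1-benzothiophen-2-yl in place of 1,3-thiazol-4-yl on a carbonyl carbon. Within the data shown here, no measured step covers a change of this size at the carbonyl carbon; the steps of a 1.3-fold higher number from compound 1 to compound 2 (0.10 log units; within the scatter) and a 6.4-fold lower number from compound 1 to compound 3 (0.81 log units; beyond the scatter) show only that exchanging one aromatic group for another there can leave the number unchanged or lower it modestly. A modest lowering is therefore expected, a 2.4-fold lower number from compound 2 to compound 4 (0.38 log units; beyond the scatter). Compound 4 is estimated at 400 nM, within 80 nM to 2000 nM.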

Compound 4, half-maximal inhibitory concentration: 86 nM
Compound 4: middle estimate off by 4.7-fold (0.67 log units), on the high side; low and high end bracket the measured number.
By their numbers in this assay, from the lowest: compounds 4 and 3 (each within the scatter of the next); then compounds 1 and 2 (each within the scatter of the next).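

In this assay the carbonyl carbon accepts the larger 5-bromo-1-benzothiophen-2-yl group, and the number falls sharply against 1,3-thiazol-4-yl (an 11-fold lower number from compound 2 to compound 4 (1.05 log units; beyond the scatter)) and against furan-2-yl (a 9.0-fold lower number from compound 1 to compound 4 (0.95 log units; beyond the scatter)). Against pyridin-2-yl the group stays within the scatter (a 1.4-fold lower number from compound 3 to compound 4 (0.14 log units; within the scatter)), so among these compounds a ring nitrogen is not required for a number in this range. No evidence is available to explain these differences. As far as these compounds go, it remains open whether the bromine or the fused six-membered ring drives the lowering, and how 1-benzothiophen-2-yl without bromine, or with a methoxy group instead, would compare.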